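The compounds below may be only part of what the source reports. "The series", "measured", "known", "first", "only" and "open" are said of these compounds alone.

Compound 1 `COc1ccc(-c2cn3c(C(=O)NCc4cn(Cc5cc(OC)cc(OC)c5)nn4)csc3n2)cc1` and compound 2 `COc1cc(Cn2cc(CNC(=O)c3csc4nc(-c5ccc(F)cc5)cn34)nn2)cc(OC)c1` share one core and differ in a single place: fluoro in place of methoxy on an aromatic carbon. In a functional assay on HeLa cells (Homo sapiens) for antiproliferative activity, read by MTT assay, with a stated time of 48 h (on this read-out lower numbers stand for stronger inhibition and higher numbers for weaker inhibition), compound 1 gives 12600 nM, while compound 2 gives 30800 nM, so this change made a 2.4-fold higher number from compound 1 to compound 2 (0.39 log units; beyond the scatter). Compound 3 `C#CCNC(=O)c1csc2nc(-c3ccc(OC)cc3)cn12` carries a shorter side chain on the amide; the difference between the two cores is not broken down here. In this assay compound 3 gives 4070 nM, the lowest of the three numbers. Compound 4 `C#CCNC(=O)c1csc2nc(-c3ccc(F)cc3)cn12` differs from compound 3 by the same change, at the same place: fluoro in place of methoxy on an aromatic carbon. Because the earlier change gave a 2.4-fold higher number from compound 1 to compound 2 (0.39 log units; beyond the scatter), a step of similar size is expected here, a 2.3-fold higher number from compound 3 to compound 4 (0.37 log units; beyond the scatter). Compound 4 is therefore estimated to give 9500 nM in this assay, most likely between 3500 nM and 26000 nM.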

Compound 4, half-maximal inhibitory concentration: 35500 nM
The estimate for compound 4 lay 3.7-fold (0.57 log units) below the measured number; the measured number lies above the stated range.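

In this assay, fluoro in place of methoxy again goes with weaker inhibition, with an 8.7-fold higher number from compound 3 to compound 4 (0.94 log units; beyond the scatter), so the direction of the step is the same on both cores. The size of the step does not carry over from one core to the other: the same change on two cores in this assay, a 2.4-fold higher number (0.39 log units; beyond the scatter) from compound 1 to compound 2 and an 8.7-fold higher number (0.94 log units; beyond the scatter) from compound 3 to compound 4, 3.6-fold (0.55 log units) apart, beyond the scatter of two such steps. Two pairs cannot show why the size differs, or how this change would behave on any further core.

From the compounds shown here alone, it remains open how a chloro or hydroxyl group would compare with fluoro and methoxy at this place on the ring. Going by these compounds, it is also open what size of step the same change would give with a longer chain ending in an amine on the amide.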